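This account rests on a few compounds, and the source may have more. Where it says the series, first, only, none or still open, it means among the compounds named here.

Of the compounds shown here, three have already been tested in a toxicity assay on THP-1 cells (Homo sapiens) for inhibition (on this read-out lower numbers stand for higher toxicity in this test and higher numbers for lower toxicity in this test), and compound 4 has not. Compound 1, with the structure `COc1ccc(-c2cnc(NC(=O)c3ccc(F)cc3)n2Cc2ccccc2)cc1`, gives in this assay a result of > 100000 nM, which is a limit of the assay rather than a number. Compound 2, `Cn1c(-c2ccccc2)cnc1NC(=O)c1ccc(F)cc1`, likewise gives in this assay the limit > 100000 nM. Compound 3, `COc1ccc(-c2cnc(NC(=O)C3CCNCC3)n2C)cc1`, also gives in this assay the limit > 100000 nM. So compound 3 stands exactly where the other two stand, at the limit of > 100000 nM in this assay, at which 3 of the 3 values shown sit, and no measured difference separates any of them.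

Compound 4, `COc1ccc(-c2cnc(NC(=O)c3ccc(O)cc3)n2C)cc1`, differs from compound 3 in one place: 4-hydroxyphenyl in place of piperidin-4-yl on a carbonyl carbon. The amide and the shared core are kept; only the group on the carbonyl carbon is exchanged, one six-membered non-aromatic ring with 1 hetero atom giving way to one six-membered aromatic ring of carbon only.

Among the measured compounds shown here, no step between two measured compounds is known here, so the size of this change cannot be read from the data. Compound 1, compound 2 and compound 3 all sit at the limit of > 100000 nM in this assay, at which 3 of the 3 values shown sit, and nothing among them points to a change beyond the scatter. The expected step is therefore a number no higher from compound 3 to compound 4 (the limit leaves the size open), none beyond the scatter, with a limit again the most likely report. In this assay compound 4 is estimated at 100000 nM, within a range from 30000 nM to 300000 nM.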

Compound 4, half-maximal cytotoxic concentration: > 100000 nM
Compound 4: no number, only a limit; the forecaster's own chance of this, stated with the estimate: 85%; the middle value sits exactly at the limit.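

Compound 3 and compound 4 each give only a limit in this assay, so no step between them can be read, and the result stays where the others stand: the limit of > 100000 nM in this assay, at which 4 of the 4 values shown sit.

The compounds shown leave open whether any change to the group on the carbonyl carbon would give a measurable number in this assay.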